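Working notes: from compound 2 to compound 3

This account rests on a few compounds, and the source may have more. Where it says the series, first, only, none or still open, it means among the compounds named here.

- Compound 1 `Cn1c(-c2ccccc2)nnc1[S+](C)[O-]`: > 100 mg/kg (a limit)
- Compound 2 `CSc1nnc(-c2ccccc2F)n1C`: > 200 mg/kg (a limit)

Both compounds were tested in a functional assay on the whole organism for antagonist activity, with Mus musculus as the target, in the maximal electroshock model (on this read-out higher numbers stand for an effect only at larger amounts of compound and lower numbers for an effect already at smaller amounts), and neither has yielded a number. Compound 2 stands only at its limit of > 200 mg/kg, so its place in the series cannot be fixed more closely. Among the measured compounds shown here, no measured step is available as a guide.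

Compound 3 `Cn1c(-c2ccccc2F)nnc1[S+](C)[O-]` keeps the 2 core of compound 2 but has one change on an aromatic carbon: a group of 3 heavy atoms (1 carbon, 1 oxygen, 1 sulfur; no ring) in place of a group of 2 heavy atoms (1 carbon, 1 sulfur; no ring), on an aromatic carbon. Compound 1 carries the same entering group and also gives only a limit, > 100 mg/kg. The evidence is therefore thin. The step of an at least 2.8-fold lower number from compound 2 to compound 3 (0.45 log units; beyond the scatter) is expected to go beyond the usual scatter, towards an effect at smaller amounts. For compound 3 the estimated value is 70 mg/kg, with an expected range from 20 mg/kg to 250 mg/kg.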

Compound 3, dose for half-maximal effect: > 200 mg/kg
Compound 3: no number, only a limit; the forecaster's own chance of this, stated with the estimate: 50%; middle value at least 2.8-fold (0.45 log units) away from the limit.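

Among the compounds shown here, compound 3 gives only a limit, > 200 mg/kg, so no step from compound 1 or compound 2 to compound 3 can be read in this assay. The compounds shown leave open whether either change shifts the read-out at all, since none of the three has yielded a number.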